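A few compounds are considered here, and "the series" means these few. Any claim that something is new, unique, unknown or untested is made for them only; others in the source may bear on it.

Measured compounds:
Compound 1, `CCCOC(=O)Nc1nc2cc(C(=O)c3cccs3)ccc2[nH]1`, in a functional assay on B16 cells (Mus musculus) for inhibition; on this read-out lower numbers stand for stronger inhibition and higher numbers for weaker inhibition: 500 nM
Compound 2, `COC(=O)Nc1nc2cc(C(=O)c3sccc3C)ccc2[nH]1`, in this assay: 2000 nM

Compound 2 holds the highest number of the two in this assay; compound 1 sits a clear distance lower, beyond the scatter. The two share the same core but differ at more than one place, so nothing isolates a single change between them.

Compound 3, `COC(=O)Nc1nc2cc(C(=O)c3ccc(C)s3)ccc2[nH]1`, keeps the core and the carbamate of compound 2 and differs only in the thienyl group: 5-methylthiophen-2-yl in place of 3-methylthiophen-2-yl on a carbonyl carbon. Within the data shown here, no step of this kind has been measured, so its size and direction are unknown. Such a rearrangement of a methyl within the same ring is expected to give at most a modest step, a 1.3-fold lower number from compound 2 to compound 3 (0.12 log units; within the scatter), with no firm direction beyond the scatter. Compound 3 is therefore estimated at 1500 nM, within a range of 500 nM to 4500 nM.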

Compound 3, half-maximal inhibitory concentration: 10000 nM
Compound 3: middle estimate off by 6.7-fold (0.82 log units), on the low side; the whole stated range lies below it.
By their numbers in this assay, from the lowest: compound 1; then compound 2; then compound 3.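

Moving the methyl within the thiophene, with 5-methylthiophen-2-yl in place of 3-methylthiophen-2-yl on a carbonyl carbon, gives a 5.0-fold higher number from compound 2 to compound 3 (0.70 log units; beyond the scatter) in this assay. Among these compounds, this is the first single-place step, and it shows that this group is sensitive to where the methyl sits: the two groups have the same atoms and the same counts, yet the step lies beyond the scatter. Nothing measured on these compounds bears on the reason for this step.

Compound 1 differs from compound 2 and compound 3 in more than one place, so the contribution of the methyl remains separate from neither the propyl nor the methyl carbamate. Also open, from the compounds shown here alone, is how a chlorine or a methoxy group in place of the methyl would read out on this ring.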